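A Changed Side Chain on the Shared Core

The compounds below may be only part of what the source reports. "The series", "measured", "known", "first", "only" and "open" are said of these compounds alone.

Of the compounds shown here, three sharing one core have been measured in an ADME assay on Vero cells (Chlorocebus sabaeus) for cytotoxicity, read by reporter gene assay, with a stated time of 4 days; a lower number here means a stronger inhibitor, a higher number a weaker inhibitor. Compound 1 `CCCC(C)C(=O)NCC(C)(C)CC1=C(O)C(=O)c2ccccc2C1=O` gives 48100 nM, compound 2 `CCCCCCC(=O)NCC(C)(C)CC1=C(O)C(=O)c2ccccc2C1=O` gives 24800 nM and compound 3 `CCCCCCCCCCC(=O)NCC(C)(C)CC1=C(O)C(=O)c2ccccc2C1=O` gives 14900 nM. Compound 2 holds the second highest of these three numbers, yet its gaps to both others lie within the scatter, with steps of a 1.9-fold lower number from compound 1 to compound 2 (0.29 log units; within the scatter) and a 1.7-fold lower number from compound 2 to compound 3 (0.22 log units; within the scatter).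

The unmeasured compound 4 `CCCCCC(=O)OCC(C)(C)CC1=C(O)C(=O)c2ccccc2C1=O` departs from compound 2 in one place: (pentylcarbonyl)oxy in place of (hexylcarbonyl)amino on a saturated chain carbon, three bonds along the chain from a double-bonded ring carbon. Here (pentylcarbonyl)oxy stands in place of (hexylcarbonyl)amino on a saturated chain carbon, three bonds along the chain from a double-bonded ring carbon. For the measured compounds named here, all three measured steps alter only the chain on the carbonyl, and none of them tests a (pentylcarbonyl)oxy group, so the data offer no direct precedent. The largest of them, a 3.2-fold lower number from compound 1 to compound 3 (0.51 log units; beyond the scatter), is modest and spans a change from 1-methylbutyl to decyl. On that evidence, no large move is expected in this assay. The expected result is a 1.0-fold higher number from compound 2 to compound 4 (0.00 log units; within the scatter), which would be no step beyond the scatter. For compound 4 the estimated value is 25000 nM, with an expected range from 10000 nM to 60000 nM.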

Compound 4, half-maximal inhibitory concentration: 169000 nM
The estimate for compound 4 lay 6.8-fold (0.83 log units) below the measured number, outside the stated range (above it).
By their numbers in this assay, from the lowest: compounds 3, 2 and 1 (each within the scatter of the next, the first and the last beyond it); then compound 4.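

For the compounds shown here, the earlier compounds changed only the chain on the carbonyl, while compound 4 is the first to change the link itself, and the number proves sensitive to that: (pentylcarbonyl)oxy in place of (hexylcarbonyl)amino gives in this assay a 6.8-fold higher number from compound 2 to compound 4 (0.83 log units; beyond the scatter) and, starting from the branched chain, a 3.5-fold higher number from compound 1 to compound 4 (0.55 log units; beyond the scatter). Going by these compounds alone, both steps lie beyond the scatter and both point the same way, so at this place, on a saturated chain carbon, three bonds along the chain from a double-bonded ring carbon, swapping the amino link for the oxy link goes with a weaker number here, and by more than any chain change among the earlier compounds did. No measurement at hand offers an explanation for this shift.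

The swap also shortens the chain from hexyl to pentyl, so the effect of the link cannot yet be separated from that of the chain, and a (hexylcarbonyl)oxy group would divide the two. On these data alone, whether a longer chain such as decyl on the oxy link would lower the number as it does on the amino link, or how a urea or a sulfonamide link would behave at this place, remains open.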